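The compounds below may be only part of what the source reports. "The series", "measured", "known", "first", "only" and "open" are said of these compounds alone.

Of the compounds shown here, three have so far been tested in an ADME assay on PA-1 cells (Homo sapiens) for cytotoxicity, read by MTT assay, with a stated time of 72 h (a lower number here means a stronger inhibitor, a higher number a weaker inhibitor), and each of them reached only the limit of that test. Compound 1 `COc1ccc(C2=C(c3cc(OC)c(OC)c(OC)c3)C(=O)C(OC(C)=O)C2)cc1F` gives > 100 ug/mL, which is a limit rather than a number. Compound 2 `COc1ccc(C2=C(c3cc(OC)c(OC)c(OC)c3)C(=O)C(O)C2)cc1F` carries hydrogen in place of acetyl on an oxygen on a saturated carbon and gives > 100 ug/mL, again a limit. The step that the two limits leave unreadable from compound 1 to compound 2 is therefore not readable. Compound 3 `CC(=O)OC1C/C(=N/O)C(c2ccccc2)=C1c1ccccc1` has a different core, and the difference between the two cores is not broken down here. In this assay compound 3 gives > 100 ug/mL, once more a limit. Compound 4 `O/N=C1/CC(O)C(c2ccccc2)=C1c1ccccc1` has not yet been measured; it carries hydrogen in place of acetyl on an oxygen on a saturated carbon, the same change as between compound 1 and compound 2, made at the same place. Because every measured value sits at the limit of > 100 ug/mL in this assay, at which 3 of the 3 values shown sit, there is no readable step from which to copy. The step that the limit leaves unreadable from compound 3 to compound 4 is therefore expected to be small. For compound 4 in this assay the estimate is 150 ug/mL, and the most likely outcome is that the test again reports only a limit.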

Compound 4, half-maximal inhibitory concentration: > 100 ug/mL
Compound 4: only a limit was reported; the forecaster's own chance of this, stated with the estimate: 85%; the middle value lies beyond the limit too.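

Compound 4 reaches only a limit, as compound 3 does, so no step from compound 3 to compound 4 can be read in this assay, because both results sit at the same ceiling: the limit of > 100 ug/mL in this assay, at which 4 of the 4 values shown sit.

The compounds shown leave open whether changing acetoxy to hydroxy alters cytotoxicity at all, on either core, since none of them gives an actual number.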